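The source may report more compounds than this note shows. Statements on the series, on what has been measured and on what is new or still open speak of the compounds shown alone.

In a functional assay (Homo sapiens) for antiproliferative activity (on this read-out higher numbers stand for weaker inhibition of growth and lower numbers for stronger inhibition of growth), compound 1 `Cc1cn2c(/C=N/NC(=N)N)c(-c3ccncc3)nc2s1` gives 34700 nM. Going by the values given here, compound 2 `Cc1sc2nc(-c3ccncc3)c(/C=N/NC(=N)N)n2c1C` gives 43700 nM, and the step of a 1.3-fold higher number from compound 1 to compound 2 (0.10 log units; within the scatter) leaves the two inside the scatter, so compound 1 stands level with the only other measured compound. Compound 3 `Cc1cn2c(/C=N/NC(=N)N)c(-c3cccnc3)nc2s1` differs from compound 1 by pyridin-3-yl in place of pyridin-4-yl on an aromatic carbon. Among the compounds with values here, no measured step covers this exchange; the single step known, methyl in place of hydrogen on an aromatic carbon, concerns another part of the shared core and stayed within the scatter. With no guide in the data, no step beyond the scatter is expected, and the estimate for compound 3 is 35000 nM, between 12000 nM and 100000 nM, meaning an expected step of a 1.0-fold higher number from compound 1 to compound 3 (0.00 log units; within the scatter).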

Compound 3, concentration for 50% growth inhibition: 7080 nM
For compound 3 the middle estimate is 4.9-fold (0.69 log units) above the measured one, outside the stated range (below it).
By their numbers in this assay, from the lowest: compound 3; then compounds 1 and 2 (each within the scatter of the next).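

In this assay the exchange of pyridin-4-yl for pyridin-3-yl gives a 4.9-fold lower number from compound 1 to compound 3 (0.69 log units; beyond the scatter) and is the only step shown that lies beyond the scatter. Two groups with the same atoms and the same counts therefore separate on this read-out, so this position responds to where the ring nitrogen sits in the pyridine. Nothing available accounts for the difference. On these data alone, how a phenyl or pyridin-2-yl group would read at this position remains open. So does whether the methyl step stays within the scatter with pyridin-3-yl in place.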